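This account rests on a few compounds, and the source may have more. Where it says the series, first, only, none or still open, it means among the compounds named here.

Compound 1 `CN1CCN(c2ccc3[nH]nc(S(=O)(=O)c4ccccc4Cl)c3c2)CC1` gives 4 nM in an assay on HeLa cells for displacement of a labelled ligand from 5-hydroxytryptamine receptor 6 (Homo sapiens); on this read-out lower numbers stand for stronger inhibition and higher numbers for weaker inhibition.
Compound 2 `COc1ccc(S(=O)(=O)c2n[nH]c3cc(N4CCNCC4)ccc23)cc1` gives 124 nM in this assay.
Compound 3 `CCCn1nc(S(=O)(=O)c2cccc3ccccc23)c2cc(N3CCNCC3)ccc21` gives 2.2 nM in this assay.

Among these three numbers, compound 1 holds the second highest. Its nearest neighbour is compound 3, whose number lies within the usual scatter of compound 1, so the two cannot be ordered on this evidence. The furthest is compound 2, whose number stands well beyond the scatter above that of compound 1; compound 2 differs from compound 1 in more than one place, so what the two values show is only that gap, not its source.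

The next compound, compound 4 `CN1CCN(c2ccc3[nH]nc(S(=O)(=O)c4ccc(Cl)cc4)c3c2)CC1`, shares all atoms with compound 1 but joins them differently: 4-chlorophenyl in place of 2-chlorophenyl on a sulfonyl sulfur. Within the data shown here, no measured pair in this set isolates such a change, so there is no step to lean on. With the chlorine shifted on the same six-membered aromatic ring, a modest move in this assay is expected, most likely toward a somewhat higher number, and possibly none beyond the scatter. Accordingly, compound 4 is estimated to give 8 nM, with a plausible range from 3 nM to 25 nM, which is expected to correspond to a step of a 2.0-fold higher number from compound 1 to compound 4 (0.30 log units; within the scatter).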

Compound 4, inhibition constant: 8.1 nM
The estimate for compound 4 lay 1.0-fold (0.01 log units) below the measured number, within the range that was stated.
By their numbers in this assay, from the lowest: compounds 3 and 1 (each within the scatter of the next); then compound 4; then compound 2.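

In this assay, among these compounds, this is the first pair in the set that differs in one place only, and it shows that the read-out responds to where the chlorine sits on the aromatic ring on the sulfonyl sulfur, with 4-chlorophenyl in place of 2-chlorophenyl giving a 2.0-fold higher number from compound 1 to compound 4 (0.31 log units; beyond the scatter). The step is modest and only just passes the usual scatter, so with the atoms unchanged and only their joining altered, the move of the chlorine shifts the number by a small amount rather than a large one. Nothing at hand accounts for the direction or the size of this step.

The compounds shown leave open how an unsubstituted phenyl, or a methyl or trifluoromethyl in place of the chlorine, would compare on this sulfonyl sulfur with the core of compound 1 kept fixed. They also leave open whether the same shift of the chlorine would give a step of similar size with a free piperazine in place of the methylpiperazine.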